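A few compounds are considered here, and "the series" means these few. Any claim that something is new, unique, unknown or untested is made for them only; others in the source may bear on it.

Compound 3 `Cc1nc(C)c(-c2nn(-c3ccc(F)cc3)cc2C2CC(c3cc(Cl)c(C)cc3O)=NN2)s1` carries a 5-chloro-2-hydroxy-4-methylphenyl group on the shared core. In an ADME assay on A549 cells (Homo sapiens) for inhibition, read by MTT assay (a higher number here means a weaker inhibitor of growth, a lower number a stronger inhibitor of growth), compound 3 gives 146 ug/mL, while compound 1 `Cc1nc(C)c(-c2nn(-c3ccc(F)cc3)cc2C2CC(c3cc(Br)ccc3O)=NN2)s1` gives 81.4 ug/mL; the two values lie within the usual scatter of each other, since a 1.8-fold higher number from compound 1 to compound 3 (0.25 log units; within the scatter). Compound 2 `Cc1nc(C)c(-c2nn(-c3ccc(F)cc3)cc2C2CC(c3cc(Cl)ccc3O)=NN2)s1` reaches only the limit of > 250 ug/mL in this assay. Compound 4 `Cc1nc(C)c(-c2nn(-c3ccc(F)cc3)cc2C2CC(c3c(O)cc(C)c(Cl)c3C)=NN2)s1` differs from compound 3 by methyl in place of hydrogen on an aromatic carbon. Among the measured compounds shown here, the one step of the same kind already measured is an at least 1.7-fold lower number from compound 2 to compound 3 (0.23 log units; that floor lies within the scatter), and for comparison an at least 3.0-fold higher number from compound 1 to compound 2 (0.48 log units; beyond the scatter). Because an at least 1.7-fold lower number from compound 2 to compound 3 (0.23 log units; that floor lies within the scatter) stayed small, a similar small shift, if any, is expected here: a 1.2-fold higher number from compound 3 to compound 4 (0.07 log units; within the scatter). Compound 4 is therefore estimated at 170 ug/mL, within a likely range from 75 ug/mL to 250 ug/mL.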

Compound 4, concentration for 50% growth inhibition: 43.4 ug/mL
For compound 4 the middle estimate is 3.9-fold (0.59 log units) above the measured one, outside the stated range (below it).
By their numbers in this assay, from the lowest: compounds 4, 1 and 3 (each within the scatter of the next, the first and the last beyond it). At a limit, above all of these: compound 2.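

Adding a methyl ortho to a chloro group can move growth inhibition beyond the scatter in this assay (a 3.4-fold lower number from compound 3 to compound 4 (0.53 log units; beyond the scatter)), which the earlier methyl step could not establish. Compound 2 stands at a limit, so its step gives only a floor (an at least 5.7-fold lower number from compound 2 to compound 4 (0.76 log units; beyond the scatter)). The gain brings this chloro series level with bromo-bearing compound 1 (a 1.9-fold lower number from compound 1 to compound 4 (0.27 log units; within the scatter)).

Going by these compounds, whether an ethyl, methoxy or amine on this carbon would give the same shift remains open. So does whether this methyl would have the same effect with bromo in place of chloro.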